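A few compounds are considered here, and "the series" means these few. Any claim that something is new, unique, unknown or untested is made for them only; others in the source may bear on it.

Going by the values given here, in a functional assay on MCF7 cells (Homo sapiens) for inhibition, read by CCK-8 assay, with a stated time of 72 h (on this read-out higher numbers stand for weaker inhibition and lower numbers for stronger inhibition), compound 2 `O=C(/C=C/c1cccnc1)NCCCCCCc1cccc(S(=O)(=O)Nc2ccc(F)c(Cl)c2)c1` gives 6.3 nM and compound 1 `CCc1ccc(NS(=O)(=O)c2cccc(CCCCCCNC(=O)/C=C/c3cccnc3)c2)cc1` gives 3.64 nM, so the only two measured values lie within the scatter of each other. Compound 3 `O=C(/C=C/c1cccnc1)NCCCCCCc1cccc(S(=O)(=O)Nc2ccc(C(F)(F)F)cc2)c1` carries 4-(trifluoromethyl)phenyl in place of 3-chloro-4-fluorophenyl on a sulfonamide nitrogen. Among the compounds with values here, one measured step bears on this change, as it falls at the same place: a 1.7-fold higher number from compound 1 to compound 2 (0.24 log units; within the scatter), with 3-chloro-4-fluorophenyl in place of 4-ethylphenyl. Within the data shown here, this single exchange gives thin evidence, and no compound with 4-(trifluoromethyl)phenyl has a value yet. On that basis, no step beyond the scatter is expected in this assay, in either direction. The step expected is a 1.1-fold lower number from compound 2 to compound 3 (0.06 log units; within the scatter). Compound 3 is expected at 5.5 nM, with an estimated range of 1.8 nM to 17 nM.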

Compound 3, half-maximal inhibitory concentration: 67.8 nM
The estimate for compound 3 lay 12-fold (1.09 log units) below the measured number; measured number above the stated range.
By their numbers in this assay, from the lowest: compounds 1 and 2 (each within the scatter of the next); then compound 3.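

With 4-(trifluoromethyl)phenyl in place of 3-chloro-4-fluorophenyl on a sulfonamide nitrogen, this assay shows an 11-fold higher number from compound 2 to compound 3 (1.03 log units; beyond the scatter) and so the aryl group at this place can move the number well beyond the scatter, which the earlier exchange, a 1.7-fold higher number from compound 1 to compound 2 (0.24 log units; within the scatter), did not show. Trifluoromethyl in place of ethyl on an aromatic carbon gives a 19-fold higher number from compound 1 to compound 3 (1.27 log units; beyond the scatter) and confirms that these aryl groups are not interchangeable here. No measurement on hand explains the gap between compound 3 and the other two compounds.

Open, going by these compounds, is where an unsubstituted phenyl, a 4-methoxyphenyl or a 4-chlorophenyl would fall on this read-out, with compounds 1 and 2 or with compound 3. Also open, on these data alone, is whether the step at this place keeps its size with a shorter chain in place of the hexyl linker.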